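The compounds below may be only part of what the source reports. "The series", "measured", "known", "first", "only" and "open" are said of these compounds alone.

Working notes on the series. Three measured compounds share the same protected spiro core and differ in the group carried on a saturated ring carbon. In a functional assay on MT4 cells (Homo sapiens) for cytotoxicity (a higher number here means that more compound is tolerated, a lower number that less compound is tolerated), compound 1 `CN(C)c1ncnc2c1ncn2[C@@H]1O[C@H](CO[Si](C)(C)C(C)(C)C)[C@@]2(OS(=O)(=O)C=C2N)[C@H]1O[Si](C)(C)C(C)(C)C` gives 15000 nM. In this assay compound 2 `CC(C)(C)[Si](C)(C)OC[C@H]1O[C@@H](n2cnc3c(N)ncnc32)[C@H](O[Si](C)(C)C(C)(C)C)[C@@]12OS(=O)(=O)C=C2N` gives 7300 nM. In this assay compound 3 `Cn1cnc2ncn([C@@H]3O[C@H](CO[Si](C)(C)C(C)(C)C)[C@@]4(OS(=O)(=O)C=C4N)[C@H]3O[Si](C)(C)C(C)(C)C)c2c1=O` gives 156000 nM. Compound 2 thus stands at the lowest of the three numbers; compound 1 is nearest and compound 3 furthest, both differences beyond the scatter. Among the compounds with values here, the only single-point step within the measured set is a 10-fold higher number from compound 1 to compound 3 (1.02 log units; beyond the scatter), an exchange of the group on the saturated ring carbon.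

Compound 4 `CC(C)(C)[Si](C)(C)OC[C@H]1O[C@@H](n2cnc3c(N)ncnc32)[C@H](O[Si](C)(C)C(C)(C)C)[C@]12OS(=O)(=O)C=C2N` is the next step from compound 2: the two compounds have the same atoms and bonds and differ only in configuration as drawn: 1 of 4 stereo elements differ; a stereocentre at a saturated ring carbon is drawn S in compound 2 and R in compound 4. Within the data shown here, no measured step in this set changes a stereocentre, and the step of a 10-fold higher number from compound 1 to compound 3 (1.02 log units; beyond the scatter) concerns a different kind of change, so nothing measured bears directly on this move. On that basis the expectation in this assay is no step beyond the scatter, with a wide band of uncertainty. For compound 4 the estimate in this assay is 7300 nM, expected range 2500 nM to 25000 nM. The implied step, no change at the digits printed from compound 2 to compound 4 (within the scatter), is expected to fall within the scatter.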

Compound 4, half-maximal cytotoxic concentration: 13000 nM
Beside the measured number, compound 4's estimate is 1.8-fold (0.25 log units) below it; low and high end bracket the measured number.
By their numbers in this assay, from the lowest: compounds 2, 4 and 1 (each within the scatter of the next, the first and the last beyond it); then compound 3.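

In this assay, within the data shown here, the first measured change of a stereocentre gives a 1.8-fold higher number from compound 2 to compound 4 (0.25 log units; within the scatter), so drawing this saturated ring carbon R rather than S leaves the number within the scatter, and the comparison concerns configuration alone: the fact that compounds 2 and 4 differ only in the configuration as drawn. Amino in place of dimethylamino on an aromatic carbon gives a 1.2-fold lower number from compound 1 to compound 4 (0.06 log units; within the scatter), also within the scatter. By contrast, the exchange of the group on the saturated ring carbon gives a 12-fold lower number from compound 3 to compound 4 (1.08 log units; beyond the scatter), so compound 3 remains well apart from compound 4, as it did from compound 1.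

From the compounds shown here alone, whether the stereocentre is equally silent when the group of compound 3 is present remains open. Also open, going by these compounds, is how the number responds to an ethylamino group or a longer alkylamino chain on that aromatic carbon.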